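Branching the ester or amide side chain in three ureas and thioureas

The source may hold more compounds than are shown below. What is called first, only, known or untested is meant among the compounds shown, and "the series" means these compounds.

Measured compounds:
- compound 1, `CCCOC(=O)C1=C(C)NC(=S)NC1c1ccoc1`: 4%
- compound 2, `CC1=C(C(=O)OCC(C)C)C(c2ccoc2)NC(=S)N1`: 12%
- compound 3, `CCNC(=O)C1=C(C)NC(=O)NC1c1ccsc1`: 3%

All three compounds were tested in an assay on membranes from CHO cells for displacement of a labelled ligand from adenosine receptor A1 (Homo sapiens), read by scintillation counting, with a stated time of 60 min, tested at 1 uM; a lower number here means less inhibition, a higher number more inhibition at the concentration tested (going by the name of the read-out). Compound 1 gives 4% and compound 2 gives 12%. The two share a core and differ in one place: methyl in place of hydrogen on a saturated chain carbon bound to two saturated chain carbons. This change made a step of a number 8 percentage points higher from compound 1 to compound 2 (within the scatter), so the two values cannot be told apart.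

Compound 3, with 3% in this assay, has a different core from compound 1; the difference between the two cores is not broken down here. Its value lies within the scatter of the other two, so no order among the three can be claimed.

Compound 4, `CC1=C(C(=O)NC(C)C)C(c2ccsc2)NC(=O)N1`, has not yet been measured in this assay. It differs from compound 3 in one place: methyl in place of hydrogen on a saturated chain carbon bound to an amide-type nitrogen and a saturated chain carbon. Among the compounds with values here, this is the same kind of change as the one from compound 1 to compound 2, but the place is not the same: there the carbon was bound to two saturated chain carbons, here it is bound to an amide-type nitrogen and a saturated chain carbon.

Within the data shown here, for compound 4 a step of about a number 4 percentage points higher from compound 3 to compound 4 (within the scatter) is expected, because the only earlier example of this kind of change is the one from compound 1 to compound 2, a number 8 percentage points higher from compound 1 to compound 2 (within the scatter), which stayed within the scatter. Compound 4 is therefore estimated at 7%, with a range from 0% to 20%.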

Compound 4, a percentage reported as inhibition, at one concentration (the size of the read-out at that concentration, not a potency): 8%
Compound 4: the middle estimate sits 1 percentage points below what was measured; the measured number falls inside the stated range.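

In this assay, the methyl that turns ethylcarbamoyl into isopropylcarbamoyl makes a step of a number 5 percentage points higher from compound 3 to compound 4 (within the scatter), so these two compounds cannot be told apart. Within the data shown here, the same kind of change, made on a chain at a different place and on a different core, looks alike in both cases: the same change on two cores in this assay, a number 8 percentage points higher (within the scatter) from compound 1 to compound 2 and a number 5 percentage points higher (within the scatter) from compound 3 to compound 4, 3 percentage points apart, within the scatter of two such steps This shows that, in both examples, adding the methyl left the result within the normal spread of repeat measurements; it does not show that the methyl has a real effect that carries from one core to another, as neither step can be told from no step at all, and two examples are too few to make a rule.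

The compounds shown leave open whether a longer chain, such as butyl or hexyl, or a chain ending in an amine or a carboxylic acid, would give a value in this assay that stands clear of the scatter. They also leave open what the core itself contributes, as compound 1 and compound 3 differ in more than one place and no single change between them can be read.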